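Swapping tert-butoxy for piperidin-1-yl on a shared core

The source may hold more compounds than are shown below. What is called first, only, known or untested is meant among the compounds shown, and "the series" means these compounds.

Measured compounds:
Compound 1 `Cc1cc(SC(C)(C)C)c(S(C)(=O)=O)cc1C(=O)N=C(N)N`: 22 nM
Compound 2 `Cc1cc(OC(C)(C)C)c(S(C)(=O)=O)cc1C(=O)N=C(N)N`: 9.4 nM

Of the compounds shown here, two have been tested in a functional assay for inhibition of sodium/hydrogen exchanger (Oryctolagus cuniculus); on this read-out lower numbers stand for stronger inhibition and higher numbers for weaker inhibition. Compound 1 gives 22 nM, and compound 2 gives 9.4 nM. Within the data shown here, the single step between them, a 2.3-fold lower number from compound 1 to compound 2 (0.37 log units; beyond the scatter), is modest but beyond the scatter, so compound 2 stands with the lower of the two numbers.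

Compound 3 `Cc1cc(N2CCCCC2)c(S(C)(=O)=O)cc1C(=O)N=C(N)N` is not yet measured. It differs from compound 2 in one place: piperidin-1-yl in place of tert-butoxy on an aromatic carbon. Among the measured compounds shown here, the only measured step, from compound 1 to compound 2, exchanged one group for another at this same aromatic carbon and moved the number by a modest amount. For the measured compounds named here, no measured step involves piperidin-1-yl, so there is no direct precedent for this change; the closest guide is that a swap at this position has so far shifted the number only modestly.

Compound 3 is therefore expected to give a number near that of compound 2, with a step of a 1.5-fold higher number from compound 2 to compound 3 (0.17 log units; within the scatter) that is not expected to exceed the scatter. The estimate for compound 3 is 14 nM, with a range from 4 nM to 50 nM.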

Compound 3, half-maximal inhibitory concentration: 21 nM
Compound 3: middle estimate off by 1.5-fold (0.18 log units), on the low side; the range from low to high includes it.
By their numbers in this assay, from the lowest: compound 2; then compounds 3 and 1 (each within the scatter of the next).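

With three groups now compared at this aromatic carbon in this assay, a group carrying a six-membered non-aromatic ring is accepted on the shared core, and piperidin-1-yl in place of tert-butoxy gives a 2.2-fold higher number from compound 2 to compound 3 (0.35 log units; beyond the scatter). Changing (tert-butyl)sulfanyl to piperidin-1-yl gives a 1.0-fold lower number from compound 1 to compound 3 (0.02 log units; within the scatter), so these two groups cannot be told apart on this read-out, while tert-butoxy is the only one of the three whose number stands clear of both others. Nothing available here accounts for this ordering, so the numbers describe what happens at this position without explaining it.

A smaller ring such as pyrrolidin-1-yl, a ring with a second hetero atom such as morpholin-4-yl, or an open-chain amine such as dimethylamino could land near piperidin-1-yl or near tert-butoxy, and the three compounds shown do not say which. On these data alone, it also remains open whether the small edge of tert-butoxy would persist if the methyl group or the methylsulfonyl group on the shared core were replaced.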